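Acetyl Enters the Aromatic Ring of a Small Urea

A few compounds are considered here, and "the series" means these few. Any claim that something is new, unique, unknown or untested is made for them only; others in the source may bear on it.

Two measured compounds share a core, and they differ only on the six-membered aromatic ring of carbon only. Compound 1 `N#CC1CN1C(=O)Nc1ccc(F)cc1` carries a fluoro there; in a functional assay on OVCAR-3 cells (Homo sapiens) for inhibition (a higher number here means a weaker inhibitor, a lower number a stronger inhibitor), compound 1 gives 5900 nM. Compound 2 `N#CC1CN1C(=O)Nc1ccccc1` carries a hydrogen in its place, and in this assay compound 2 gives 6800 nM. Compound 2 thus holds the higher of the two numbers seen so far, but the step of a 1.2-fold higher number from compound 1 to compound 2 (0.06 log units; within the scatter) lies within the scatter, so the two compounds cannot be told apart on these measurements.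

Compound 3 `CC(=O)c1cccc(NC(=O)N2CC2C#N)c1` is the one still to be measured. It differs from compound 2 by acetyl in place of hydrogen on an aromatic carbon. Among the compounds with values here, the only measured step, a 1.2-fold higher number from compound 1 to compound 2 (0.06 log units; within the scatter), concerns a fluoro rather than an acetyl and was itself within the scatter, so nothing measured speaks directly to this change. With no pointer in either direction, the step of a 1.0-fold lower number from compound 2 to compound 3 (0.02 log units; within the scatter) is expected to stay within the scatter. In this assay compound 3 is therefore estimated at 6500 nM, most likely between 2200 nM and 19000 nM.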

Compound 3, half-maximal inhibitory concentration: 10000 nM
Beside the measured number, compound 3's estimate is 1.5-fold (0.19 log units) below it; measured number inside the range.
By their numbers in this assay, from the lowest: compounds 1, 2 and 3 (each within the scatter of the next).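

Acetyl on the aromatic carbon, meta to a group of 8 heavy atoms, gives a 1.5-fold higher number from compound 2 to compound 3 (0.17 log units; within the scatter) in this assay and so leaves compound 3 indistinguishable from compound 2 on these measurements. Within the data shown here, the only earlier step exchanged a single fluoro for hydrogen, whereas this one places a group of 3 heavy atoms, with a double bond outside the aromatic ring and a hydrogen-bond acceptor, on the ring, and the read-out still cannot separate the two compounds. This position can therefore carry a larger group than a lone hydrogen while inhibition of these cells stays measurable and within the scatter of the parent compound, and nothing available accounts for this outcome.

A single acetyl cannot show whether other groups at this place would behave in the same way, such as an amine, a carboxylic acid or a longer chain ending in a carbonyl. On these data alone, it also remains open whether acetyl would give a similar reading on another carbon of the ring, or whether any change here could move the number beyond the scatter.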